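Replacing the 2-methoxybenzyl group with ethyl: working notes

The source may hold more compounds than are shown below. What is called first, only, known or untested is meant among the compounds shown, and "the series" means these compounds.

Measured in a functional assay on cells (Platelet, Homo sapiens) for inhibition (on this read-out higher numbers stand for weaker inhibition and lower numbers for stronger inhibition), each value a limit:
- compound 1 `CCOC(=O)c1cccc(-c2n[nH]c3ccccc23)c1`: > 10000 nM
- compound 2 `CCOC(=O)c1ccc(-c2nn(Cc3cccc(Cl)c3)c3ccccc23)cc1`: > 10000 nM
- compound 3 `CCOC(=O)c1ccc(-c2nn(Cc3ccccc3OC)c3ccccc23)cc1`: > 10000 nM

Compound 3 stands only at a limit, with no number behind it: the limit of > 10000 nM in this assay, at which 3 of the 3 values shown sit. The next change leads to compound 4 `CCOC(=O)c1ccc(-c2nn(CC)c3ccccc23)cc1`: methyl in place of 2-methoxyphenyl on a saturated chain carbon bound to an aromatic nitrogen. Among the measured compounds shown here, the one measured step at this place is a step that the two limits leave unreadable from compound 2 to compound 3, so it offers no size and no direction. Nothing measured points to a gain in this assay, and the expected outcome is no readable change. The estimated step is a step that the limit leaves unreadable from compound 3 to compound 4. Compound 4 is expected at 15000 nM, within an estimated range of 5000 nM to 50000 nM, and most likely again as a limit.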

Compound 4, half-maximal inhibitory concentration: > 10000 nM
Compound 4: a limit, no number; the forecaster's own chance of this, stated with the estimate: 85%; the middle value is on the limit's open side.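

Among the compounds shown here, compound 4 gives > 10000 nM, again a limit, so no step to it from compound 2 or compound 3 can be read. The compounds shown leave open whether these groups differ at all in inhibition: the limit of > 10000 nM in this assay, at which 4 of the 4 values shown sit.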